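From ethyl to tert-butyl on the shared core

The compounds below may be only part of what the source reports. "The series", "measured", "known", "first", "only" and "open" are said of these compounds alone.

Results in a functional assay (aorta) with Rattus norvegicus as the target (on this read-out lower numbers stand for an effect already at smaller amounts and higher numbers for an effect only at larger amounts of compound), so far:
- compound 1 `CCC1(C)C=C(/C(S)=N\C)c2cc([N+](=O)[O-])ccc2O1` gives 0.182 nM here
- compound 2 `CCC1(CC)C=C(/C(S)=N\C)c2cc([N+](=O)[O-])ccc2O1` gives 0.372 nM here
- compound 3 `CCC1C=C(/C(S)=N\C)c2cc([N+](=O)[O-])ccc2O1` gives < 31700 nM as a limit

The result for compound 3 is < 31700 nM and this is a limit of the assay, not a number. Compound 3 therefore has no exact place on the scale.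

Compound 4 `C/N=C(/S)C1=CC(C(C)(C)C)Oc2ccc([N+](=O)[O-])cc21` has not been measured yet. It carries tert-butyl in place of ethyl on a saturated ring carbon and this carbon sits next to the ring oxygen.

Two measured steps change a group on a saturated ring carbon, yet a step that the limit leaves unreadable from compound 1 to compound 3 and a step that the limit leaves unreadable from compound 2 to compound 3 give no size. Within the data shown here, the only readable step is a 2.0-fold higher number from compound 1 to compound 2 (0.31 log units; beyond the scatter) and it is small, with methyl in place of hydrogen on a saturated chain carbon. This is a weak guide for a change of this size in this assay and the direction is uncertain. The expected change is a step that the limit leaves unreadable from compound 3 to compound 4 with wide uncertainty. Compound 4 is expected at 1000 nM with an estimated range from 20 nM to 30000 nM here.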

Compound 4, half-maximal effective concentration: 0.398 nM
Estimate against measurement, compound 4: 2500-fold (3.40 log units) above; measured number outside the range, below it.
By their numbers in this assay, from the lowest: compound 1; then compounds 2 and 4 (each within the scatter of the next).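

No size can be read for the step between compound 3 and compound 4, because compound 3 has only a limit and no exact number: the limit of < 31700 nM in this assay, at which 1 of the 4 values shown sits.

The compounds shown therefore leave open how large the change from ethyl to tert-butyl on this saturated ring carbon is, and in which direction it runs.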